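A new group where formyl once stood

The compounds below may be only part of what the source reports. "The series", "measured", "known", "first", "only" and "open" are said of these compounds alone.

Of the compounds shown here, two have been measured in an assay on CHO cells for inhibition of metabotropic glutamate receptor 1 (Rattus norvegicus); a lower number here means a stronger inhibitor, a higher number a weaker inhibitor. Compound 1 `CCCOC(=O)c1[nH]c(C=O)c(C(=O)OC(C)(C)C)c1C` gives 2000 nM, while compound 2 `CCCOC(=O)c1[nH]cc(C(=O)OC(C)(C)C)c1C` gives 75 nM, the lowest of the two numbers. The step of a 27-fold lower number from compound 1 to compound 2 (1.43 log units; beyond the scatter) shows that taking the formyl group away lowers the number strongly. Compound 3 `CCCOC(=O)c1[nH]c(C(=O)Sc2ccccn2)c(C(=O)OC(C)(C)C)c1C` comes next: ((pyridin-2-yl)sulfanyl)carbonyl in place of hydrogen on an aromatic carbon, placed next to the ring nitrogen and next to the ring atom that bears a tert-butoxycarbonyl group. This is the very position that carried formyl in compound 1, so the measured step bears directly on it, but runs the other way: a carbonyl-bearing group enters rather than leaves. Because a 27-fold lower number from compound 1 to compound 2 (1.43 log units; beyond the scatter) was large, the new group is expected to raise the number in this assay again, though the entering group is not formyl and the size is uncertain. For compound 3 the estimated step is an 11-fold higher number from compound 2 to compound 3 (1.03 log units; beyond the scatter). Compound 3 is therefore expected to give 800 nM, within 150 nM to 4000 nM.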

Compound 3, half-maximal inhibitory concentration: 3200 nM
For compound 3 the middle estimate is 4.0-fold (0.60 log units) below the measured one; the range from low to high includes it.
By their numbers in this assay, from the lowest: compound 2; then compounds 1 and 3 (each within the scatter of the next).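

Hydrogen is the only group at this position so far that goes with a low number: in this assay the change to ((pyridin-2-yl)sulfanyl)carbonyl brings a 43-fold higher number from compound 2 to compound 3 (1.63 log units; beyond the scatter) and so the high range seen with formyl returns with a quite different carbonyl-bearing group. Putting (pyridin-2-yl)sulfanyl on the carbonyl carbon in place of hydrogen gives a 1.6-fold higher number from compound 1 to compound 3 (0.20 log units; within the scatter) so this added part makes no readable difference once a carbonyl stands at this position. Nothing measured here explains why either group goes with a higher number than hydrogen.

As far as these compounds go, whether the carbonyl itself matters, or any group other than hydrogen at this position would do the same, stays open. A methyl group or an amine here, neither with a carbonyl, would separate these two readings.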